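Solubility of a Fused-Ring Amine: From Phenyl to Pyrimidine

A few compounds are considered here, and "the series" means these few. Any claim that something is new, unique, unknown or untested is made for them only; others in the source may bear on it.

This piece concerns two measured compounds and one that has yet to be tested, all built on the same fused two-ring core. Compound 1 `Cc1cc(NCc2nccn2C)n2nc(C)c(-c3ccccc3)c2n1` is one of the measured pair. In a physicochemical assay for solubility, read by HPLC, using the shake flask method, measured as kinetic solubility, with a stated time of 2 h, at pH 7.4 (a higher number here means a more soluble compound, a lower number a less soluble compound), compound 1 gives 26900 nM. Compound 2 `Cc1cc(NCc2ccccn2)n2ncc(-c3ccccc3C)c2n1` is the other, and in this assay compound 2 reaches only < 5000 nM, which is a limit of the assay rather than a number. Among the values shown, compound 2 therefore stands at the floor, since (the limit of < 5000 nM in this assay, at which 1 of the 2 values shown sits).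

Compound 3 `Cc1cc(NCc2ccccn2)n2ncc(-c3cncnc3)c2n1` is the unmeasured compound. It differs from compound 2 in one place: pyrimidin-5-yl in place of 2-methylphenyl on an aromatic carbon. For the measured compounds named here, no step between two measured compounds is available to calibrate this change, so the expectation rests on the structural change alone. The estimated step from compound 2 to compound 3 in this assay is an at least 4.0-fold higher number from compound 2 to compound 3 (0.60 log units; beyond the scatter), an expected rise in solubility beyond the usual scatter. Compound 3 is therefore expected to give about 20000 nM in this assay, within a range from 4000 nM to 80000 nM.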

Compound 3, solubility: 111000 nM
Compound 3: middle estimate off by 5.6-fold (0.74 log units), on the low side; measured number outside the range, above it.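

In this assay, replacing 2-methylphenyl with pyrimidin-5-yl on an aromatic carbon of the five-membered ring gives an at least 22-fold higher number from compound 2 to compound 3 (1.34 log units; beyond the scatter). For the compounds shown here, this is the first step between two measured compounds that differ in one place, and it shows that a single ring swap at this position can move the read-out by a large amount. Compound 2 gives < 5000 nM, which is a limit of the assay and not a number, so the size of the step has only a lower bound: the limit of < 5000 nM in this assay, at which 1 of the 3 values shown sits.

The swap changes several things at once, as the methyl group leaves, the ring goes from carbon only to one with 2 hetero atoms, and the group goes from 0 to 2 hydrogen-bond acceptors, so this single step cannot say which of these matters. A plain phenyl would isolate the methyl group and a pyridin-3-yl would isolate the second ring nitrogen, while a morpholine or a carboxylic acid at this place would show how other kinds of group compare with pyrimidin-5-yl.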